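The source may hold more compounds than are shown below. What is called first, only, known or untested is meant among the compounds shown, and "the series" means these compounds.

Compound 1, `CS/C(=N\C(=O)c1csc([N+](=O)[O-])c1)NC(=O)c1csc([N+](=O)[O-])c1`, and compound 2, `CS/C(=N\C(=O)c1cc2ccccc2s1)NC(=O)c1cc2ccccc2s1`, are built on two different cores, and the difference between the two cores is not broken down here. In a functional assay on K562 cells (Homo sapiens) for cytotoxicity, read by MTT assay, with a stated time of 72 h (a higher number here means a weaker inhibitor of growth, a lower number a stronger inhibitor of growth), compound 1 gives 98700 nM. In this assay compound 2 gives 66600 nM, a number that lies within the usual scatter of the number for compound 1. Compound 3, `O=C(/N=C(/NC(=O)c1csc([N+](=O)[O-])c1)[Se]Cc1ccccc1)c1csc([N+](=O)[O-])c1`, is derived from compound 1 by one change: a group of 8 heavy atoms (7 carbon, 1 selenium; one six-membered aromatic ring of carbon only) in place of a group of 2 heavy atoms (1 carbon, 1 sulfur; no ring), on a carbon with a double bond to nitrogen. In this assay compound 3 gives 55800 nM, so that the step of a 1.8-fold lower number from compound 1 to compound 3 (0.25 log units; within the scatter) is itself within the scatter, and the number for compound 3 also lies within the scatter of that for compound 2.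

Compound 4, `O=C(/N=C(/NC(=O)c1cc2ccccc2s1)[Se]Cc1ccccc1)c1cc2ccccc2s1`, has not yet been measured. It stands to compound 2 as compound 3 stands to compound 1: a group of 8 heavy atoms (7 carbon, 1 selenium; one six-membered aromatic ring of carbon only) in place of a group of 2 heavy atoms (1 carbon, 1 sulfur; no ring), on a carbon with a double bond to nitrogen. The place is described in the same words for both pairs, so the change is the same one, made here on the core of compound 2 instead of the core of compound 1. Going by the values given here, the step from compound 2 to compound 4 is estimated to be a 1.7-fold lower number from compound 2 to compound 4 (0.22 log units; within the scatter), because the same change on the other core gave a 1.8-fold lower number from compound 1 to compound 3 (0.25 log units; within the scatter), a step within the scatter, and there is only this one example to rest on. In this assay compound 4 is therefore expected to give 40000 nM, with an estimated range from 15000 nM to 110000 nM.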

Compound 4, concentration for total growth inhibition: 42800 nM
Estimate against measurement, compound 4: 1.1-fold (0.03 log units) below, within the range that was stated.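

In this assay, putting the group of 8 heavy atoms with its selenium and six-membered aromatic ring in place of methylsulfanyl, on the core of compound 2, gives a 1.6-fold lower number from compound 2 to compound 4 (0.19 log units; within the scatter), and set beside the earlier step on the other core it agrees with it: the same change on two cores in this assay, a 1.8-fold lower number (0.25 log units; within the scatter) from compound 1 to compound 3 and a 1.6-fold lower number (0.19 log units; within the scatter) from compound 2 to compound 4, 1.1-fold (0.06 log units) apart, within the scatter of two such steps. On these two cores, then, the change carries over with a step of like size, and the core of compound 2 gives no sign of answering differently from the core of compound 1. This does not show that the change has any real effect on growth inhibition, since each step lies within the scatter and the agreement is one between two small steps, and two cores give no rule for other cores in the series.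

The compounds shown leave open whether any such step belongs to the selenium or to the aromatic ring, as both enter together and a benzylsulfanyl group, with sulfur in place of the selenium, would be needed to part them. They also leave open how a longer alkyl chain on the selenium, or an amine on the carbon with a double bond to nitrogen, would read in this assay.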